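Propionamide sulfonates: iodo for isopropyl on the phenol ring

A few compounds are considered here, and "the series" means these few. Any claim that something is new, unique, unknown or untested is made for them only; others in the source may bear on it.

Measured so far:
compound 1, `CC(=O)Nc1ccc(S(=O)(=O)Oc2ccccc2C(C)C)cc1` — 21000 nM
compound 2, `CC(=O)Nc1ccc(S(=O)(=O)Oc2ccccc2I)cc1` — 27000 nM
compound 3, `CCC(=O)Nc1ccc(S(=O)(=O)Oc2ccccc2C(C)C)cc1` — 11000 nM

All three numbers come from a functional assay on M21 cells (Homo sapiens) for antiproliferative activity, read by sulforhodamine B assay, with a stated time of 48 h; on this read-out lower numbers stand for stronger inhibition and higher numbers for weaker inhibition. Compound 3 gives the lowest number of the three, but its gap to compound 1 is within the scatter; only the gap to compound 2 lies beyond it. The steps seen so far are a 1.3-fold higher number from compound 1 to compound 2 (0.11 log units; within the scatter) and a 1.9-fold lower number from compound 1 to compound 3 (0.28 log units; within the scatter).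

Compound 4 is `CCC(=O)Nc1ccc(S(=O)(=O)Oc2ccccc2I)cc1`. From compound 3 the change is iodo in place of isopropyl on an aromatic carbon, in the place ortho to a large group. The same change has been run once before, as the step from compound 1 to compound 2, which stayed within the scatter. No step beyond the scatter is therefore expected here; compound 4 is estimated at 14000 nM, with a range from 7000 nM to 30000 nM, meaning an expected step of a 1.3-fold higher number from compound 3 to compound 4 (0.10 log units; within the scatter).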

Compound 4, half-maximal inhibitory concentration: 11000 nM
For compound 4 the middle estimate is 1.3-fold (0.10 log units) above the measured one; the measured number falls inside the stated range.
By their numbers in this assay, from the lowest: compounds 3, 4, 1 and 2 (each within the scatter of the next, the first and the last beyond it).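

Iodo in place of isopropyl, ortho to a large group, now reads the same way on a second core, with no change at the digits printed from compound 3 to compound 4 (within the scatter), so this assay does not separate these two groups at this position: the same change on two cores in this assay, a 1.3-fold higher number (0.11 log units; within the scatter) from compound 1 to compound 2 and no change at the digits printed (within the scatter) from compound 3 to compound 4, 1.3-fold (0.11 log units) apart, within the scatter of two such steps. The added methyl on the saturated chain carbon bound to a carbonyl carbon now gives a 2.5-fold lower number from compound 2 to compound 4 (0.39 log units; beyond the scatter), a step beyond the scatter, and it agrees with the step on the other core: the same change on two cores in this assay, a 1.9-fold lower number (0.28 log units; within the scatter) from compound 1 to compound 3 and a 2.5-fold lower number (0.39 log units; beyond the scatter) from compound 2 to compound 4, 1.3-fold (0.11 log units) apart, within the scatter of two such steps.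

Open, from the compounds shown here alone, is how an amine or a methoxy group in place of iodo would read at this position. Also open, going by these compounds, is whether a longer chain on the carbonyl carbon would extend the step seen with the added methyl.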